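Switching an Alkyl Amide Substituent to Fluorophenyl

The source may hold more compounds than are shown below. What is called first, only, known or untested is meant among the compounds shown, and "the series" means these compounds.

Compound 3 `COc1cc2nccc(Oc3ccc(Nc4nn(C)cc4C(=O)NCC4CCCO4)cc3)c2cc1C(N)=O` is one of three compounds with a shared core that differ only in the group on an amide-type nitrogen. In a functional assay on BaF3 cells (Mus musculus) for antiproliferative activity, read by CCK-8 assay and cell counting, with a stated time of 76 h (on this read-out higher numbers stand for weaker inhibition and lower numbers for stronger inhibition), compound 3 gives only a limit, > 10000 nM. Compound 1 `COc1cc2nccc(Oc3ccc(Nc4nn(C)cc4C(=O)NOCc4ccccc4)cc3)c2cc1C(N)=O` likewise reaches only a limit, > 10000 nM. Compound 2 `COc1cc2nccc(Oc3ccc(Nc4nn(C)cc4C(=O)NCC4CCCCC4)cc3)c2cc1C(N)=O` also gives a limit, > 10000 nM. All three therefore sit at the limit of > 10000 nM in this assay, at which 3 of the 3 values shown sit, and the steps among them, a step that the two limits leave unreadable from compound 1 to compound 2, a step that the two limits leave unreadable from compound 1 to compound 3 and a step that the two limits leave unreadable from compound 2 to compound 3, cannot be read in size. Compound 3 thus stands at the same limit as the other two, with no measured number to place it higher or lower than either.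

Compound 4 `COc1cc2nccc(Oc3ccc(Nc4nn(C)cc4C(=O)Nc4ccc(F)cc4)cc3)c2cc1C(N)=O` has not yet been measured. Its difference from compound 3 is 4-fluorophenyl in place of (oxolan-2-yl)methyl on an amide-type nitrogen. For the measured compounds named here, none of the measured steps offers a readable size, and all three concern saturated groups on that nitrogen, so they bear on this change only by showing that three such groups leave the limit unbroken. The step from compound 3 to compound 4 is therefore expected to be an at least 1.6-fold lower number from compound 3 to compound 4 (0.22 log units; that floor lies within the scatter), with its direction uncertain. Compound 4 is estimated at 6000 nM in this assay, within a range from 600 nM to 40000 nM.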

Compound 4, half-maximal inhibitory concentration: 3060 nM
Estimate against measurement, compound 4: 2.0-fold (0.29 log units) above; measured number inside the range.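

In this assay, compound 4 is the only one of the four to give a number rather than a limit, while the other three compounds remain at that limit: the limit of > 10000 nM in this assay, at which 3 of the 4 values shown sit. For the compounds shown here, the steps among compounds 1, 2 and 3 cannot be read, but 4-fluorophenyl on the amide-type nitrogen gives the first readable steps at this position (an at least 3.2-fold lower number from compound 3 to compound 4 (0.51 log units; beyond the scatter)) (an at least 3.2-fold lower number from compound 2 to compound 4 (0.51 log units; beyond the scatter)) (an at least 3.2-fold lower number from compound 1 to compound 4 (0.51 log units; beyond the scatter)), each beyond the scatter and each a floor rather than a full size. The group on this nitrogen can therefore shift the read-out, though not simply through the presence of an aromatic ring, as compound 1 carries one in its benzyloxy group and still stays at the limit.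

A single fluorinated compound cannot separate the part played by the fluorine from that of the ring itself, a question that plain phenyl or 4-chlorophenyl on the same nitrogen would address. Nor do the compounds shown say whether the ring must sit directly on the nitrogen, which 4-fluorobenzyl would test, or how far compounds 1, 2 and 3 lie beyond their limit.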